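A 4-methylphenyl group on compound 2

The source may report more compounds than this note shows. Statements on the series, on what has been measured and on what is new or still open speak of the compounds shown alone.

Compound 2 `O=C1COc2ccc(-c3cccc(NS(=O)(=O)c4ccc(F)cc4)c3)cc2N1` was tested in a functional assay on HepG2 cells (Homo sapiens) for antiproliferative activity, read by MTT assay, with a stated time of 72 h; on this read-out lower numbers stand for stronger inhibition and higher numbers for weaker inhibition. In this assay compound 2 gives > 40000 nM, which is a limit of the assay and not a number. Compound 3 `Cc1ccc(N2C(=O)COc3ccc(-c4cccc(NS(=O)(=O)c5ccc(F)cc5)c4)cc32)cc1` keeps the core of compound 2 and changes in one place: 4-methylphenyl in place of hydrogen on an amide-type nitrogen in a ring. Compound 1 `COc1cccc(N2C(=O)COc3ccc(-c4cnc(Cl)c(NS(=O)(=O)c5ccc(F)cc5)c4)cc32)c1`, which also carries an aromatic ring on that nitrogen, gives > 40000 nM, again a limit of the assay. Among the compounds with values here, the measurements so far thus end at the limit of > 40000 nM in this assay, at which 2 of the 2 values shown sit, and no measured step shows the size of such a change. In this assay no shift beyond the scatter is therefore expected. The expected step is a number no higher from compound 2 to compound 3 (the limit leaves the size open). For compound 3 the estimated half-maximal inhibitory concentration is 40000 nM, with an expected range from 15000 nM to 80000 nM.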

Compound 3, half-maximal inhibitory concentration: > 40000 nM
Compound 3: a limit, no number; the forecaster's own chance of this, stated with the estimate: 70%; the middle value lies on the limit itself.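

In this assay compound 3 gives > 40000 nM, a limit of the assay and not a number. Within the data shown here, compound 2 also stands at a limit, so no step from it to compound 3 can be read. The compounds shown leave open what size of effect the 4-methylphenyl group has, and all of them rest at the same point: the limit of > 40000 nM in this assay, at which 3 of the 3 values shown sit.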